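Bromo in Place of Trifluoromethyl on a Shared Core

A few compounds are considered here, and "the series" means these few. Any claim that something is new, unique, unknown or untested is made for them only; others in the source may bear on it.

Compound 2 `O=S(=O)(NC1=NCCN1C(=S)SN1CCn2c1nsc2=S)c1ccc(C(F)(F)F)cc1` belongs to a small set of three compounds tested in a functional assay on KYSE-510 cells (Homo sapiens) for antiproliferative activity, read by crystal violet staining, with a stated time of 96 h; on this read-out lower numbers stand for stronger inhibition of growth and higher numbers for weaker inhibition of growth. In this assay compound 2 gives >= 20000 nM, which is a limit of the assay and not a number. Compound 1 `Cc1ccc(S(=O)(=O)NC2=NCCN2C(=S)SN2CCn3c2nsc3=S)cc1` gives >= 20000 nM in this assay, also a limit. Compound 3 `COc1ccc(S(=O)(=O)NC2=NCCN2C(=S)SN2CCn3c2nsc3=S)cc1` gives >= 20000 nM, a limit as well. The measured steps between them are a step that the two limits leave unreadable from compound 1 to compound 2, a step that the two limits leave unreadable from compound 1 to compound 3 and a step that the two limits leave unreadable from compound 2 to compound 3; all three values sit at the limit of >= 20000 nM in this assay, at which 3 of the 3 values shown sit. Compound 4 `O=S(=O)(NC1=NCCN1C(=S)SN1CCn2c1nsc2=S)c1ccc(Br)cc1` differs from compound 2 by bromo in place of trifluoromethyl on an aromatic carbon. Among the measured compounds shown here, no measured step can be read in size, so none of them gives a direction for this change; the only thing the three values share is the limit. Compound 4 is therefore expected to stay at that same limit, the expected step being a step that the limit leaves unreadable from compound 2 to compound 4. The estimate for compound 4 is 25000 nM, with a range from 8000 nM to 80000 nM.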

Compound 4, concentration for 50% growth inhibition: >= 20000 nM
Compound 4: a limit, no number; the forecaster's own chance of this, stated with the estimate: 80%; the middle value does not contradict the limit.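

Compound 4 gives >= 20000 nM in this assay, a limit of the assay and not a number. No step between compound 4 and compound 1, compound 2 or compound 3 can be read, and all four compounds share one limit: the limit of >= 20000 nM in this assay, at which 4 of the 4 values shown sit.

The compounds shown leave open how strongly any of them inhibits growth, and whether the group on the aromatic ring changes that at all.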